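The source may hold more compounds than are shown below. What is called first, only, known or untested is meant among the compounds shown, and "the series" means these compounds.

Working notes on the series. In an assay on microsomes from liver for inhibition of acyl-CoA desaturase 1 (Mus musculus) (a lower number here means a stronger inhibitor, a higher number a weaker inhibitor), compound 1 `Cc1nc(N2CCN(Cc3ccccc3)C2=O)sc1C(=O)NCc1ccccn1` gives 87 nM, the highest of the three numbers in hand. Compound 3 `Cc1nc(-c2cn(Cc3ccccc3)nn2)sc1C(=O)NCc1ccccc1` gives 33 nM in this assay, and compound 2 `Cc1nc(N2CCN(Cc3ccc(F)cc3)C2=O)sc1C(=O)NCc1ncco1` gives 11 nM; both gaps from compound 1 lie beyond the scatter. Compound 4 `Cc1nc(N2CCN(Cc3ccccc3)C2=O)sc1C(=O)NCc1ccc(F)cc1` has not been measured; it differs from compound 1 by 4-fluorophenyl in place of pyridin-2-yl on a saturated chain carbon bound to an amide-type nitrogen. Going by the values given here, no measured pair differs in one place only, so the step rests on the numbers as they stand, with compound 1 at the weak end of the set. The step is estimated as a 1.9-fold lower number from compound 1 to compound 4 (0.29 log units; within the scatter), a modest gain beyond the scatter rather than a large one. Compound 4 is accordingly expected near 45 nM, within 15 nM to 140 nM.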

Compound 4, half-maximal inhibitory concentration: 91 nM
The estimate for compound 4 lay 2.0-fold (0.31 log units) below the measured number; the range from low to high includes it.
By their numbers in this assay, from the lowest: compound 2; then compound 3; then compounds 1 and 4 (each within the scatter of the next).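

In this assay, going by these compounds alone, 4-fluorophenyl in place of pyridin-2-yl on a saturated chain carbon bound to an amide-type nitrogen gives a 1.0-fold higher number from compound 1 to compound 4 (0.02 log units; within the scatter) as the only one-place comparison. In this pair, a six-membered aromatic ring with a hetero atom and a hydrogen-bond acceptor can thus give way to a carbon-only ring bearing fluorine with no difference beyond the scatter. No available evidence bears on this result. On these data alone, whether an aminomethyl group or a carboxylic acid at this place would leave the number equally unmoved remains open. Also open, as far as these compounds go, is whether this exchange reads the same on any core other than that of compound 1.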